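Compound 3 to compound 4: expecting a lower number

A few compounds are considered here, and "the series" means these few. Any claim that something is new, unique, unknown or untested is made for them only; others in the source may bear on it.

In a functional assay on cells (Homo sapiens) for cytotoxicity, read by MTT assay, with a stated time of 24 h (on this read-out higher numbers stand for weaker inhibition and lower numbers for stronger inhibition), compound 1 (`CCCCCCCCCCCCCCNC(=O)[C@H](CO)/N=C/c1cccc(OC)c1`) gives 31300 nM and compound 2 (`CCCCCCCCCCCCCCNC(=O)[C@H](CO)/N=C/c1ccc(OC)cc1`) gives 28100 nM, with a 1.1-fold lower number from compound 1 to compound 2 (0.05 log units; within the scatter) separating them. Compound 3 (`CCCCCCCCCCCCCCNC(=O)[C@H](CO)NCc1ccccc1O`), at 75300 nM, has the highest number of the three and so the weakest inhibition.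

Compound 4 (`CCCCCCCCCCCCCCNC(=O)[C@H](CO)/N=C/c1ccccc1O`) differs from compound 3 on a saturated chain carbon bound to a carbonyl carbon and a saturated chain carbon, where the (2-hydroxybenzyl)amino group gives way to a group with a double bond outside the aromatic ring: a group of 9 heavy atoms (7 carbon, 1 nitrogen, 1 oxygen; one six-membered aromatic ring of carbon only) in place of a group of 9 heavy atoms (7 carbon, 1 nitrogen, 1 oxygen; one six-membered aromatic ring of carbon only), on a saturated chain carbon bound to a carbonyl carbon and a saturated chain carbon.

Going by the values given here, two measured steps bear on this: a 2.4-fold higher number from compound 1 to compound 3 (0.38 log units; beyond the scatter) and a 2.7-fold higher number from compound 2 to compound 3 (0.43 log units; beyond the scatter). Both are modest, and both lead to the group without that double bond. Compound 4 moves the opposite way, so a step of similar size towards a lower number is expected. The transfer is uncertain, since no ring with the same substituents has been measured in both forms.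

The expected change is a 2.7-fold lower number from compound 3 to compound 4 (0.43 log units; beyond the scatter). Compound 4 is estimated at 28000 nM, within an expected range of 12000 nM to 58000 nM.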

Compound 4, half-maximal inhibitory concentration: 19000 nM
For compound 4 the middle estimate is 1.5-fold (0.17 log units) above the measured one; measured number inside the range.
By their numbers in this assay, from the lowest: compounds 4, 2 and 1 (each within the scatter of the next); then compound 3.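

Going by these compounds alone, with the 2-hydroxyphenyl ring present on both sides, a 4.0-fold lower number from compound 3 to compound 4 (0.60 log units; beyond the scatter) in this assay isolates the change from the (2-hydroxybenzyl)amino group to the group with a double bond outside the aromatic ring, whereas the earlier steps to compound 3 also changed the ring substituents. Among the compounds with a carbon double-bonded to nitrogen, a 1.5-fold lower number from compound 2 to compound 4 (0.17 log units; within the scatter) and a 1.6-fold lower number from compound 1 to compound 4 (0.22 log units; within the scatter) both lie within the scatter, so 2-hydroxyphenyl cannot be told apart from 4-methoxyphenyl or 3-methoxyphenyl here. No evidence is available that accounts for the step from compound 3 to compound 4.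

The compounds shown leave open whether the same step would appear with either methoxyphenyl ring. They also leave open how a ring carrying an amine or a carboxylic acid, or a shorter chain on the amide nitrogen, would read in this assay.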